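This account rests on a few compounds, and the source may have more. Where it says the series, first, only, none or still open, it means among the compounds named here.

Working notes on the series. Compound 1 `Cc1c(Br)sc(N)c1C(=O)c1ccc(Cl)cc1`, compound 2 `Nc1sc(-c2ccccc2)c(-c2ccccc2)c1C(=O)c1ccc(Cl)cc1` and compound 3 `CC(C)(C)Cc1c(-c2ccccn2)sc(N)c1C(=O)c1ccc(Cl)cc1` share the same core and were all measured in an assay on CHO cells for displacement of a labelled ligand from adenosine receptor A3 (Homo sapiens), read by scintillation counting, tested at 10 uM; on this read-out lower numbers stand for less inhibition and higher numbers for more inhibition at the one concentration tested (going by the name of the read-out). In this assay compound 1 gives 1%, compound 2 gives 1% and compound 3 gives 1%. Compound 3 therefore stands level with compounds 1 and 2 at the digits shown; neither the gap to compound 1 nor the gap to compound 2 reaches beyond the scatter, so no order among the three can be read from these numbers. Compound 4 `CC(C)(C)Cc1c(-c2ccc(Cl)cc2)sc(N)c1C(=O)c1ccc(Cl)cc1` has not yet been measured in this assay. It differs from compound 3 by 4-chlorophenyl in place of pyridin-2-yl on an aromatic carbon. For the measured compounds named here, no step among the measured compounds is available to calibrate this exchange; the three measured values sit together at the bottom of the scale, and nothing in them points either up or down. The step from compound 3 to compound 4 in this assay is therefore expected to be a number 1 percentage points higher from compound 3 to compound 4 (within the scatter), that is, none beyond the scatter. For compound 4 the estimated read-out in this assay is 2%, with a range from -5% to 12%.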

Compound 4, a percentage reported as inhibition, at one concentration (the size of the read-out at that concentration, not a potency): 1%
For compound 4 the middle estimate is 1 percentage points above the measured one, and the stated range covers the measured number.
By their numbers in this assay, from the lowest: compounds 1, 2, 3 and 4 (each within the scatter of the next).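

In this assay, for the compounds shown here, the exchange of pyridin-2-yl for 4-chlorophenyl on the aromatic carbon next to the ring sulfur gives no change at the digits printed from compound 3 to compound 4 (within the scatter) and is the first single-place step. With the neopentyl group kept, the read-out at this position thus does not respond to losing the ring nitrogen and gaining a chlorine. No measured finding on hand accounts for this result. Still open, as far as these compounds go, is whether an amine or a carboxylic acid on this aromatic carbon, or a longer chain in place of neopentyl, would move the read-out beyond the scatter.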